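A few compounds are considered here, and "the series" means these few. Any claim that something is new, unique, unknown or untested is made for them only; others in the source may bear on it.

Measured in a functional assay on MCF7 cells (Homo sapiens) for cytotoxicity, read by MTT assay, with a stated time of 4 h; a higher number here means a weaker inhibitor, a lower number a stronger inhibitor:
Compound 1 `CCC(=O)OC[C@H]1O[C@@H](O[C@@H]2OC=C(C(=O)OC)[C@H]3C[C@H](OC(C)=O)[C@H](C)[C@@H]23)[C@H](OC(C)=O)[C@@H](OC(C)=O)[C@@H]1OC(C)=O` gives 1.88 ug/mL
Compound 2 `CCCCCCCCCCCCCC(=O)OC[C@H]1O[C@@H](O[C@@H]2OC=C(C(=O)OC)[C@H]3C[C@H](OC(C)=O)[C@H](C)[C@@H]23)[C@H](OC(C)=O)[C@@H](OC(C)=O)[C@@H]1OC(C)=O` gives 24.6 ug/mL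

Compound 1 holds the lower of the two numbers, and so the stronger inhibition, in this assay at 1.88 ug/mL on this scale. The next structure is compound 3 `C=CC(=O)OC[C@H]1O[C@@H](O[C@@H]2OC=C(C(=O)OC)[C@H]3C[C@H](OC(C)=O)[C@H](C)[C@@H]23)[C@H](OC(C)=O)[C@@H](OC(C)=O)[C@@H]1OC(C)=O`, which differs from compound 1 as follows: vinyl in place of ethyl on a carbonyl carbon. In words, this is vinyl in place of ethyl on a carbonyl carbon, and the shared core stays the same.

Going by the values given here, the only measured step is a 13-fold higher number from compound 1 to compound 2 (1.12 log units; beyond the scatter) and it lies beyond the scatter. That step places undecyl on a saturated chain carbon, a change of another kind, since vinyl for ethyl does not lengthen the chain. Among the compounds with values here, it therefore gives no direct measure for compound 3, and the series holds no measured example of a vinyl group. No step beyond the scatter is expected, and no direction can be assigned with confidence. The estimate amounts to an expected 1.0-fold higher number from compound 1 to compound 3 (0.00 log units; within the scatter) for now. Compound 3 is expected at 1.9 ug/mL in this assay with an estimated range from 0.7 ug/mL to 5.5 ug/mL on this read-out.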

Compound 3, half-maximal inhibitory concentration: "not active" (no number reported)
Compound 3 has no reported number here, and the estimate cannot be compared.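

Going by these compounds alone, compound 3 carries the label "not active" in this assay with no number reported, so no step from compound 1 to compound 3 can be read, and compound 1 stays at 1.88 ug/mL. No measurement shown explains this result. The compounds shown leave open how vinyl in place of ethyl on the carbonyl carbon shifts the number on this scale.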